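The source may hold more compounds than are shown below. What is called first, only, known or untested is meant among the compounds shown, and "the series" means these compounds.

Compound 1 `O=C(C1CCCO1)N1CC(c2nc(-c3cccc(Cl)c3)no2)C1` and compound 2 `O=C(C1CCC2(CCC2)CC1)N1CC(c2nc(-c3cccc(Cl)c3)no2)C1` share one core and differ only in the group attached to the carbonyl carbon. In an assay on HEK293 cells for negative allosteric modulation of metabotropic glutamate receptor 5 (Homo sapiens), read by FLIPR (a higher number here means a weaker inhibitor, a lower number a stronger inhibitor), compound 1 gives 890 nM. For compound 2 this assay reports only a limit, > 10000 nM, not a number. Among the compounds with values here, the one measured step, an at least 11-fold higher number from compound 1 to compound 2 (1.05 log units; beyond the scatter), is therefore a large weakening, and its exact size is open because the limit of > 10000 nM in this assay, at which 1 of the 2 values shown sits, caps what can be read. Compound 2 thus stands at the weak end of the two values shown.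

Compound 3 `CC1CN(C(=O)N2CC(c3nc(-c4cccc(Cl)c4)no3)C2)CC(C)O1` keeps the core of compound 2 and changes the same position again: a group of 8 heavy atoms (6 carbon, 1 nitrogen, 1 oxygen; one six-membered non-aromatic ring with 2 hetero atoms) in place of a group of 9 heavy atoms (9 carbon; one four-membered non-aromatic ring of carbon only, one six-membered non-aromatic ring of carbon only), on a carbonyl carbon. Within the data shown here, the group that enters is closer in its count of hetero atoms to the group carried by compound 1 than to the one carried by compound 2. Among the measured compounds shown here, no measured step covers this exact exchange, so the expectation rests on the single step from compound 1 to compound 2 and on the value of compound 1. Compound 3 is therefore expected to move back toward a stronger inhibitor, a step of an at least 4.0-fold lower number from compound 2 to compound 3 (0.60 log units; beyond the scatter). The estimate for compound 3 in this assay is 2500 nM, with a range from 600 nM to 10000 nM.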

Compound 3, half-maximal inhibitory concentration: 990 nM
Estimate against measurement, compound 3: 2.5-fold (0.40 log units) above; the range from low to high includes it.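

In this assay, putting 2,6-dimethylmorpholin-4-yl on the carbonyl carbon in place of the all-carbon group of compound 2 gives an at least 10-fold lower number from compound 2 to compound 3 (1.00 log units; beyond the scatter). The two groups are close in heavy-atom count, with 8 against 9. The second comparison, a 1.1-fold higher number from compound 1 to compound 3 (0.05 log units; within the scatter), shows that oxolan-2-yl and the larger 2,6-dimethylmorpholin-4-yl cannot be told apart in this test, so among these three compounds the two groups with a ring oxygen stand together and the all-carbon group stands apart. From the compounds shown here alone, the true size of the step from the all-carbon group stays open because compound 2 is known only as a limit: the limit of > 10000 nM in this assay, at which 1 of the 3 values shown sits.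

These compounds do not separate the ring oxygen from the other differences between the groups, and a 3,5-dimethylpiperidin-1-yl group, which has a ring carbon where the morpholine has its oxygen, would test this directly. An unsubstituted morpholin-4-yl group would likewise show what the two methyl groups contribute at this carbonyl carbon.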